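The compounds below may be only part of what the source reports. "The series", "measured", "known", "first", "only" and "open" are said of these compounds alone.

Compound 1 `CCCCc1ccc(-c2c(C)[nH]c(=O)n2C2CCCCC2)cc1`: 27100 nM
Compound 2 `CCCCc1ccc(-c2c(C)[nH]c(=O)n2-c2ccccc2)cc1`: compound 2 gives 16600 nM

In a functional assay on brain (Rattus norvegicus, strain Wistar) for inhibition (a higher number here means a weaker inhibitor, a lower number a stronger inhibitor), compound 1 stands at the higher of the two numbers, yet the gap to compound 2 is within the scatter: a 1.6-fold lower number from compound 1 to compound 2 (0.21 log units; within the scatter). Compound 3 `CCCCCCOc1ccc(-c2c(C)[nH]c(=O)n2C2CCCCC2)cc1` differs from compound 1 in one place: hexyloxy in place of butyl on an aromatic carbon. Within the data shown here, the only measured step concerns phenyl in place of cyclohexyl on an aromatic nitrogen and does not touch this position, so no measured step bears on this change. No step beyond the scatter is therefore expected: for compound 3 the estimate in this assay is 27000 nM (range 8000 nM to 90000 nM), an expected step of a 1.0-fold lower number from compound 1 to compound 3 (0.00 log units; within the scatter).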

Compound 3, half-maximal inhibitory concentration: 8500 nM
Estimate against measurement, compound 3: 3.2-fold (0.50 log units) above, and the stated range covers the measured number.
By their numbers in this assay, from the lowest: compounds 3, 2 and 1 (each within the scatter of the next, the first and the last beyond it).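

Among these compounds, the position on the aromatic carbon of the six-membered ring, untouched by the earlier compounds, proves responsive in this assay: hexyloxy in place of butyl gives a 3.2-fold lower number from compound 1 to compound 3 (0.50 log units; beyond the scatter), a modest step, but the first here beyond the scatter. The change on the aromatic nitrogen had stayed within it. Nothing measured here accounts for this step.

The compounds shown leave open whether the step follows the longer chain or the added oxygen, which a hexyl or a butoxy group at this place would separate. They also leave open whether hexyloxy acts alike with phenyl on the aromatic nitrogen, and what an amine or a carboxylic acid at the chain's end would give.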